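A few compounds are considered here, and "the series" means these few. Any claim that something is new, unique, unknown or untested is made for them only; others in the source may bear on it.

Working notes on the series.

Three compounds have numbers in a physicochemical assay for solubility, in phosphate buffer, measured as kinetic solubility, with a stated time of 1 h, at pH 7.4; on this read-out higher numbers stand for higher solubility and lower numbers for lower solubility. Compound 1, `CCCc1cc(OCC(=O)Nc2cc(C)cc(C)c2)c2cc(OC)ccc2n1`, gives 12000 nM in this assay. Compound 2, `COc1ccc2nc(C)cc(NC(=O)C(=O)Nc3cc(C)cc(C)c3)c2c1`, gives 10000 nM in this assay. Compound 3, `COc1ccc2nc(C)cc(OCC(=O)NCc3cc(C)cc(C)c3)c2c1`, gives 92000 nM in this assay, the highest of the three numbers; its gap to compound 1 and its gap to compound 2 both lie beyond the usual scatter, so compound 3 stands alone at the top of this set.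

The next compound, compound 4, `COc1ccc2nc(C)cc(OCC(=O)Nc3noc(C)c3C)c2c1`, has not yet been measured in this assay. It differs from compound 3 in one place:

4,5-dimethyl-1,2-oxazol-3-yl in place of 3,5-dimethylbenzyl on an amide-type nitrogen

Within the data shown here, no pair of measured compounds in this set differs in one place only, so there is no measured step to lean on for the size of this change. With compound 3 giving 92000 nM in this assay and nothing comparable measured, the step is expected to stay within the scatter, leaning if anything toward a slightly lower number, as a 1.5-fold lower number from compound 3 to compound 4 (0.19 log units; within the scatter). Compound 4 is therefore estimated at 60000 nM in this assay, within a range of 15000 nM to 200000 nM.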

Compound 4, solubility: 196000 nM
Estimate against measurement, compound 4: 3.3-fold (0.51 log units) below, and the stated range covers the measured number.
By their numbers in this assay, from the lowest: compounds 2 and 1 (each within the scatter of the next); then compound 3; then compound 4.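

On the amide-type nitrogen whose other neighbour is the carbonyl carbon, the series now has its first measured single change: in this assay the swap gives a 2.1-fold higher number from compound 3 to compound 4 (0.33 log units; beyond the scatter) for 4,5-dimethyl-1,2-oxazol-3-yl in place of 3,5-dimethylbenzyl. The number at this position therefore responds to the group placed there, modestly but past the scatter, and it moves upward. The entering group brings a five-membered aromatic ring with 2 hetero atoms and 2 hydrogen-bond acceptors, yet nothing measured ties the step to either feature.

As far as these compounds go, this one swap changes the ring and the link to the nitrogen together, so the part that carries the step stays open. A plain phenyl, or a 1,2-oxazol-3-yl stripped of its methyl groups, on this nitrogen would separate those parts.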